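A few compounds are considered here, and "the series" means these few. Any claim that something is new, unique, unknown or untested is made for them only; others in the source may bear on it.

Working notes on the series. Among the compounds with values here, in a functional assay on DU-145 cells (Homo sapiens) for inhibition, read by trypan blue exclusion, with a stated time of 96 h (on this read-out lower numbers stand for stronger inhibition of growth and higher numbers for weaker inhibition of growth), compound 3 (`O=C(/C(=C\c1ccc(Br)cc1)SCc1ccc(Cl)cc1)c1ccc(Cl)cc1`) gives 1000 nM as the lowest of the three numbers so far, while compound 1 (`Cc1ccsc1/C=C(/SCc1ccc(Cl)cc1)C(=O)c1ccc(Cl)cc1`) gives 50000 nM and compound 2 (`Cc1ccc(CS/C(=C/c2c(O)cc(O)cc2O)C(=O)c2ccc(Cl)cc2)cc1`) gives 50000 nM on the same measure. The next analogue is compound 4 (`O=C(/C(=C\c1c(O)cc(O)cc1O)SCc1ccc(Cl)cc1)c1ccc(Cl)cc1`), and the change from compound 3 is 2,4,6-trihydroxyphenyl in place of 4-bromophenyl on a double-bonded chain carbon bound to a double-bonded chain carbon on the shared core, with 2,4,6-trihydroxyphenyl in place of 4-bromophenyl on a double-bonded chain carbon bound to a double-bonded chain carbon.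

Within the data shown here, one measured step bears directly on this place: a 50-fold lower number from compound 1 to compound 3 (1.70 log units; beyond the scatter) is large and lies beyond the scatter, and it runs toward 4-bromophenyl. Compound 2 already carries 2,4,6-trihydroxyphenyl at this place, though it differs elsewhere on the core, and it stands at 50000 nM in this assay without a direct partner for comparison. Losing 4-bromophenyl is therefore expected to give a large step toward a higher number and weaker inhibition of growth, set somewhat smaller than the measured one. The expected change is a 20-fold higher number from compound 3 to compound 4 (1.30 log units; beyond the scatter) in this estimate. The estimated value of compound 4 is 20000 nM with an expected range from 4000 nM to 60000 nM in this series.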

Compound 4, concentration for 50% growth inhibition: > 100000 nM
Compound 4 gave a limit, no number; the forecaster's own chance of this, stated with the estimate: 15%; middle value at least 5.0-fold (0.69 log units) away from the limit.
By their numbers in this assay, from the lowest: compound 3; then compounds 1 and 2 (each within the scatter of the next). At a limit, above all of these: compound 4.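

In this assay compound 4 reads > 100000 nM, which is a limit and not a number, and it is the only compound of the series to sit there: the limit of > 100000 nM in this assay, at which 1 of the 4 values shown sits.

On the shared core, the place on a double-bonded chain carbon bound to a double-bonded chain carbon now has a direct pair for 2,4,6-trihydroxyphenyl, which compound 2 could not give: 2,4,6-trihydroxyphenyl in place of 4-bromophenyl gives an at least 100-fold higher number from compound 3 to compound 4 (2.00 log units; beyond the scatter), a large step toward weaker inhibition of growth. With chloro in place of methyl on an aromatic carbon there is an at least 2.0-fold higher number from compound 2 to compound 4 (0.30 log units; that floor lies within the scatter), and with 2,4,6-trihydroxyphenyl in place of 3-methylthiophen-2-yl on a double-bonded chain carbon bound to a double-bonded chain carbon there is an at least 2.0-fold higher number from compound 1 to compound 4 (0.30 log units; that floor lies within the scatter). The floor of each of these two steps lies within the scatter, so neither exchange receives an order here.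

The compounds shown leave open whether the lower number of compound 3 depends on the bromine itself, since a plain phenyl or a 4-chlorophenyl at this place would be needed to separate the atom from the ring. They also leave open how a single hydroxyl, as in 4-hydroxyphenyl, or a 4-aminophenyl would read on the same core in this assay.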